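This account rests on a few compounds, and the source may have more. Where it says the series, first, only, none or still open, it means among the compounds named here.

Measured in a functional assay (mast cells) for inhibition, with Rattus norvegicus as the target; on this read-out lower numbers stand for an effect already at smaller amounts and higher numbers for an effect only at larger amounts of compound:
- Compound 1 `CCOC(=O)c1cnc2n(c1=O)C(C)CC/C2=N\Nc1cccc(C(=O)O)c1`: 740000 nM
- Compound 2 `CC1CC/C(=N\Nc2cccc(Br)c2)c2ncc(C(=O)O)c(=O)n21`: 6700 nM

Of these two, compound 2 has the lower number, 6700 nM, while compound 1 stands at 740000 nM, a gap beyond the usual scatter. The two compounds differ in more than one place, so no single-change comparison is available to show what a new group on this part of the molecule does.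

Compound 3 `CC1CC/C(=N\Nc2ccc(O)cc2)c2ncc(C(=O)O)c(=O)n21` carries 4-hydroxyphenyl in place of 3-bromophenyl on an amine nitrogen. Among the compounds with values here, with no direct precedent, only a modest shift towards a higher number is expected in this assay, far smaller than the gap between the two measured compounds, and the direction remains uncertain. The expected change is a 2.2-fold higher number from compound 2 to compound 3 (0.35 log units; beyond the scatter). For compound 3 the estimated value is 15000 nM, with an expected range of 3000 nM to 80000 nM.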

Compound 3, half-maximal effective concentration: 1300 nM
Compound 3: middle estimate off by 12-fold (1.06 log units), on the high side; the whole stated range lies above it.
By their numbers in this assay, from the lowest: compound 3; then compound 2; then compound 1.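

In this assay, within the data shown here, the exchange of 3-bromophenyl for 4-hydroxyphenyl on the amine nitrogen gives a 5.2-fold lower number from compound 2 to compound 3 (0.71 log units; beyond the scatter) as the first single-change reading at this position. The bromine is therefore not needed for activity in this pair, and the aryl group that carries a hydrogen-bond donor and acceptor goes with the lower number. Nothing measured here accounts for this shift.

The step changes both the substituent and its place on the phenyl ring, so it cannot say which of the two matters, and 3-hydroxyphenyl or 4-bromophenyl would be needed to separate them. As far as these compounds go, it also remains open whether the hydroxyl hydrogen counts, which 4-methoxyphenyl could test, and how unsubstituted phenyl would compare.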